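Swapping a Methyl for Fluoro on a Sulfonamide Ring

This account rests on a few compounds, and the source may have more. Where it says the series, first, only, none or still open, it means among the compounds named here.

Of the compounds shown here, three have been measured in a functional assay on MCF7 cells (Homo sapiens) for antiproliferative activity, read by MTT assay, with a stated time of 48 h (a lower number here means a stronger inhibitor, a higher number a weaker inhibitor), and a fourth awaits its number. Compound 1 has the structure `Cc1ccc(S(=O)(=O)NC(=O)c2cncc(Br)c2)cc1` and in this assay compound 1 gives 9370 nM. Compound 2, `O=C(NS(=O)(=O)c1ccc(F)cc1)c1cncc(Br)c1`, gives 980 nM in this assay. Going by the values given here, the single change between them is fluoro in place of methyl on an aromatic carbon, and it made the number move a 9.6-fold lower number from compound 1 to compound 2 (0.98 log units; beyond the scatter).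

Compound 3, `Cc1ccc(S(=O)(=O)NC(=O)c2ccc(Cl)nc2)cc1`, carries a different core; how its core differs from that of compound 1 is not broken down here. In this assay compound 3 gives 17200 nM, the highest of the three numbers, though its gap to compound 1 lies within the usual scatter.

Compound 4, `O=C(NS(=O)(=O)c1ccc(F)cc1)c1ccc(Cl)nc1`, is compound 3 with the same change applied: fluoro in place of methyl on an aromatic carbon. Because the earlier step of a 9.6-fold lower number from compound 1 to compound 2 (0.98 log units; beyond the scatter) was clearly beyond the scatter, a similar drop is expected here, tempered by the fact that it rests on a single pair. Compound 4 is therefore expected to show a 6.9-fold lower number from compound 3 to compound 4 (0.84 log units; beyond the scatter), which translates into an estimated 2500 nM, likely between 800 nM and 8000 nM.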

Compound 4, half-maximal inhibitory concentration: 16800 nM
Beside the measured number, compound 4's estimate is 6.7-fold (0.83 log units) below it; measured number above the stated range.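

In this assay the swap of fluoro in place of methyl gives a 1.0-fold lower number from compound 3 to compound 4 (0.01 log units; within the scatter), so on this core it produces no difference that can be told from the scatter. A change that gave a clear step on one core therefore did not give one on the other, and the two steps cannot be treated as the same: the same change on two cores in this assay, a 9.6-fold lower number (0.98 log units; beyond the scatter) from compound 1 to compound 2 and a 1.0-fold lower number (0.01 log units; within the scatter) from compound 3 to compound 4, 9.3-fold (0.97 log units) apart, beyond the scatter of two such steps. Going by these compounds alone, this does not show why the cores part ways, since each core offers only a single pair, and nothing here says which difference between the core of compound 1 and the core of compound 3 matters or how the swap would behave on a third core.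

The compounds shown leave open whether another group on that same aromatic carbon, such as a methoxy group or an amine, would follow the pattern of the core of compound 1 or that of compound 3. Also open, as far as these compounds go, is how either pair would respond if a nitrile or a carboxylic acid took the place of the halogen on the core.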